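A few compounds are considered here, and "the series" means these few. Any claim that something is new, unique, unknown or untested is made for them only; others in the source may bear on it.

Going by the values given here, only two compounds have been measured so far in a functional assay on PC-3 cells (Homo sapiens) for antiproliferative activity, read by MTT assay, with a stated time of 24 h; on this read-out lower numbers stand for stronger inhibition and higher numbers for weaker inhibition. Compound 1 `CCn1c(C(=O)NC2(CO)CC2)ccc1C(CC)(CC)c1ccc(OCS(=O)(=O)c2ccccc2)c(C)c1` gives 3560 nM, while compound 2 `CCn1c(C(=O)NCCCO)ccc1C(CC)(CC)c1ccc(OCS(=O)(=O)c2ccccc2)c(C)c1` gives 11300 nM, the higher of the two numbers and so the weaker inhibition. They differ only in the group on the amide-type nitrogen, where 3-hydroxypropyl replaces 1-(hydroxymethyl)cyclopropyl. This change gives a 3.2-fold higher number from compound 1 to compound 2 (0.50 log units; beyond the scatter), a modest step and the only measured one that bears on what comes next.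

Compound 3 `CCn1c(C(=O)N[C@H](CO)CCCO)ccc1C(CC)(CC)c1ccc(OCS(=O)(=O)c2ccccc2)c(C)c1` changes the same place again: a group of 7 heavy atoms (5 carbon, 2 oxygen; no ring) in place of a group of 4 heavy atoms (3 carbon, 1 oxygen; no ring), on an amide-type nitrogen. The entering group has no ring and has a defined stereocentre. Like the group in compound 1, it is not a plain unbranched chain, and compound 1 holds the lower number at 3560 nM. One pair is thin evidence, and the new group differs from both earlier ones, so this is only a rough guide. In this assay, a modest move towards a lower number is expected, of about the same size as the measured step, and the estimate is a 2.3-fold lower number from compound 2 to compound 3 (0.35 log units; beyond the scatter). The expected value for compound 3 is 5000 nM, with an estimated range of 1800 nM to 14000 nM.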

Compound 3, half-maximal inhibitory concentration: 6810 nM
Estimate against measurement, compound 3: 1.4-fold (0.13 log units) below; the measured number falls inside the stated range.
By their numbers in this assay, from the lowest: compounds 1, 3 and 2 (each within the scatter of the next, the first and the last beyond it).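

In this assay, the group of 7 heavy atoms on the amide-type nitrogen, with its 2 hydrogen-bond donors and 1 defined stereocentre, cannot be told apart from either earlier group, as the two new steps show (a 1.7-fold lower number from compound 2 to compound 3 (0.22 log units; within the scatter); a 1.9-fold higher number from compound 1 to compound 3 (0.28 log units; within the scatter)). Going by these compounds alone, this position therefore takes a larger group with an extra hydrogen-bond donor and no ring without a readable gain or loss against 3-hydroxypropyl or 1-(hydroxymethyl)cyclopropyl, and the only step here beyond the scatter is still the one between those two groups (a 3.2-fold higher number from compound 1 to compound 2 (0.50 log units; beyond the scatter)). Nothing among the available data offers an explanation for these numbers.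

The mirror-image form of the group in compound 3 would show whether its defined stereocentre matters at all, and a 3-hydroxypropyl chain carrying a small branch but no second oxygen would help separate the effect of branching from that of the added oxygen. From the compounds shown here alone, how an amine, a carboxylic acid or a longer chain such as 4-hydroxybutyl on this nitrogen would read in this assay also remains open.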